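The source may hold more compounds than are shown below. What is called first, only, known or untested is meant among the compounds shown, and "the series" means these compounds.

Of the compounds shown here, three built on one shared core have been tested in an ADME assay on BJ cells (Homo sapiens) for cytotoxicity, read by CellTiter-Glo and resazurin assay, with a stated time of 72 h; on this read-out lower numbers stand for an effect already at smaller amounts and higher numbers for an effect only at larger amounts of compound. Compound 1 `CC(C)N(Cc1cccc(OCCCCCC(=O)O)c1)C(=O)c1ccc(-c2cccc(OCc3ccccc3)c2)cc1` gives in this assay a value of > 26000 nM, which is a limit of the assay rather than a number. Compound 2 `Cc1nnc(-c2cccc(-c3ccc(C(=O)N(Cc4cccc(OCCCCCC(=O)O)c4)C(C)C)cc3)c2)o1` gives in this assay a value of > 26000 nM, again a limit. Compound 3 `CC(C)N(Cc1cccc(OCCCCCC(=O)O)c1)C(=O)c1ccc(-c2cccc(OC(F)(F)F)c2)cc1` gives in this assay a value of > 26000 nM, once more a limit. Because all three sit at the limit of > 26000 nM in this assay, at which 3 of the 3 values shown sit, none of the steps among them can be read: the change a step that the two limits leave unreadable from compound 1 to compound 2, the change a step that the two limits leave unreadable from compound 1 to compound 3 and the change a step that the two limits leave unreadable from compound 2 to compound 3 all remain of unknown size. Compound 3 therefore stands exactly where compounds 1 and 2 stand, at the limit, with no readable number of its own.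

Compound 4 `CC(C)N(Cc1cccc(OCCCCCC(=O)O)c1)C(=O)c1ccc(-c2cccc(Cl)c2)cc1` differs from compound 3 in one place (chloro in place of trifluoromethoxy on an aromatic carbon). Within the data shown here, no measured step tells how this change acts in this assay; every step so far has been hidden by the limit. Compound 4 is expected at about 26000 nM, between 10000 nM and 100000 nM, because compounds 1, 2 and 3 all stand at the limit of > 26000 nM in this assay, at which 3 of the 3 values shown sit. The expected step of a number no higher from compound 3 to compound 4 (the limit leaves the size open) is one of no readable size, with a further limit the most likely outcome.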

Compound 4, half-maximal effective concentration: > 21900 nM
Compound 4 ended at the assay's limit; the forecaster's own chance of this, stated with the estimate: 85%; the middle value is on the limit's open side.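

Compound 4, like compounds 1, 2 and 3, ended at a limit in this assay rather than at a number, so no step among these four compounds can be read. The compounds shown leave open at what concentration any of them would affect these cells, and whether chloro, trifluoromethoxy, benzyloxy or 5-methyl-1,3,4-oxadiazol-2-yl makes any difference.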